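Phenyl in place of bromo on the shared core

The source may report more compounds than this note shows. Statements on the series, on what has been measured and on what is new or still open speak of the compounds shown alone.

Of the compounds shown here, three of the shared core have been measured in a functional assay on the whole organism (strain Sprague-Dawley CD) for inhibition, with Rattus norvegicus as the target, read by paw edema, at a dose of 100 mg/kg by the oral route; on this read-out lower numbers stand for a weaker effect and higher numbers for a stronger effect at the one dose given. Compound 1 `CCOC(=O)C(=O)Nc1ccccc(C)c1=O` gives 34% in this assay. Compound 2 `CCOC(=O)C(=O)Nc1ccccc(Br)c1=O` gives 0%, and compound 3 `CCOC(=O)C(=O)Nc1ccccc(N(C)C(=O)C(=O)OCC)c1=O` gives 0%. Within the data shown here, compound 2 thus stands level with compound 3 at the digits reported, and the two together are the lowest of the three numbers; the one measured step, a number 34 percentage points lower from compound 1 to compound 2 (beyond the scatter), lies beyond the scatter and is the only gap seen so far in this assay.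

Compound 4 `CCOC(=O)C(=O)Nc1ccccc(-c2ccccc2)c1=O` differs from compound 2 by phenyl in place of bromo on an aromatic carbon. Among the measured compounds shown here, the single step that bears on this change is a number 34 percentage points lower from compound 1 to compound 2 (beyond the scatter), a large drop when bromo replaced a methyl at the same aromatic carbon of the seven-membered aromatic ring. Compound 4 puts a carbon group back at that carbon, though a phenyl rather than a methyl, and nothing measured shows how a phenyl compares with a methyl there. A rise of a number 15 percentage points higher from compound 2 to compound 4 (beyond the scatter) is therefore expected, with wide uncertainty. Compound 4 is estimated at 15% in this assay, within a range from 0% to 40%.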

Compound 4, a percentage reported as inhibition, in the whole organism at one dose (the size of the read-out at that dose, not a potency): 0%
Estimate against measurement, compound 4: 15 percentage points above, within the range that was stated.
By their numbers in this assay, from the lowest: compounds 2, 3 and 4 (each within the scatter of the next); then compound 1.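

In this assay phenyl in place of bromo gives no change at the digits printed from compound 2 to compound 4 (within the scatter) and so does not restore a response: putting a carbon group back at this aromatic carbon is not sufficient in itself. Phenyl in place of methyl gives a number 34 percentage points lower from compound 1 to compound 4 (beyond the scatter) and matches the earlier loss with bromo, a number 34 percentage points lower from compound 1 to compound 2 (beyond the scatter) so that among compounds 1, 2 and 4 only the methyl of compound 1 leaves a response at this dose, with no compound among these three going against that. No measurement at hand bears on why this is so.

From the compounds shown here alone, whether the response depends narrowly on methyl stays open, as ethyl, methoxy or plain hydrogen at this carbon would test that. Readings at a single dose also leave open whether any effect of compounds 2 and 4 would appear at other doses.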